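The source may report more compounds than this note shows. Statements on the series, on what has been measured and on what is new or still open speak of the compounds shown alone.

Compound 1 `CCOC(=O)c1cnn(CC(C)O)c1NC(=O)Nc1ccc(F)cc1`: 0.2 nM
Compound 2 `CCOC(=O)c1cnn(CC(C)O)c1NC(=O)NCc1ccccc1`: 0.00054 nM

Both values come from a functional assay on cells (Neutrophil, Homo sapiens) for inhibition, with a stated time of 10 min (a higher number here means a weaker inhibitor, a lower number a stronger inhibitor), and compound 2 has the lower number, making it the stronger inhibitor of the pair. Compound 3 `CCOC(=O)c1cnn(CC(C)O)c1NC(=O)Nc1cccc(F)c1` has 3-fluorophenyl in place of benzyl on an amide-type nitrogen of compound 2: 3-fluorophenyl in place of benzyl on an amide-type nitrogen. Within the data shown here, one measured step bears on this: a 370-fold lower number from compound 1 to compound 2 (2.57 log units; beyond the scatter), a large change on swapping 4-fluorophenyl for benzyl. Returning to a fluorophenyl should therefore largely reverse that step, giving a large rise in this assay, although no measurement yet covers 3-fluorophenyl. The expected change is a 370-fold higher number from compound 2 to compound 3 (2.57 log units; beyond the scatter). For compound 3 the estimated value is 0.2 nM, with an expected range of 0.02 nM to 2 nM.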

Compound 3, half-maximal inhibitory concentration: 0.0007 nM
Compound 3: middle estimate off by 290-fold (2.46 log units), on the high side; the measured number lies below the stated range.
By their numbers in this assay, from the lowest: compounds 2 and 3 (each within the scatter of the next); then compound 1.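

In this assay, swapping benzyl for a fluorophenyl on this amide-type nitrogen need not cost activity: 3-fluorophenyl and benzyl stay within the scatter (a 1.3-fold higher number from compound 2 to compound 3 (0.11 log units; within the scatter)). The place of the fluorine on the ring matters here, as moving from 4-fluorophenyl to 3-fluorophenyl gives a large change (a 290-fold lower number from compound 1 to compound 3 (2.46 log units; beyond the scatter)). No measurement shown here accounts for this difference. From the compounds shown here alone, it remains open whether plain phenyl or 3-chlorophenyl on this nitrogen would read like compounds 2 and 3 or like compound 1. Going by these compounds, a longer chain, such as 2-phenylethyl, also remains untested in these compounds.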